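Urea inhibitors: a hydroxymethylphenyl variant on the cyclopentane

This account rests on a few compounds, and the source may have more. Where it says the series, first, only, none or still open, it means among the compounds named here.

Measured so far:
- compound 1 `CC(C)c1cccc(C(C)C)c1NC(=O)NCC1(c2ccc(Cl)cc2)CCCC1`: 32 nM
- compound 2 `COc1cccc(C2(CNC(=O)Nc3c(C(C)C)cccc3C(C)C)CCCC2)c1`: 13 nM

In an assay on microsomes for inhibition of acyl-CoA:cholesterol acyltransferase (Oryctolagus cuniculus) (on this read-out lower numbers stand for stronger inhibition and higher numbers for weaker inhibition), compound 1 gives 32 nM. Compound 2, in this assay, gives 13 nM. Among the two numbers known, compound 1 stands highest, and its nearest neighbour is compound 2, reached by a 2.5-fold lower number from compound 1 to compound 2 (0.39 log units; beyond the scatter), a change of 3-methoxyphenyl in place of 4-chlorophenyl on a saturated ring carbon.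

Compound 3 `CC(C)c1cccc(C(C)C)c1NC(=O)NCC1(c2cccc(CO)c2)CCCC1` has not yet been measured. It differs from compound 1 as follows: 3-(hydroxymethyl)phenyl in place of 4-chlorophenyl on a saturated ring carbon. Within the data shown here, the only measured step that bears on this change is the one from compound 1 to compound 2, where a different 3-substituted phenyl replaced the same 4-chlorophenyl and produced a modest move to a lower number. The 3-(hydroxymethyl)phenyl of compound 3 is not the same group as the 3-methoxyphenyl of compound 2, so that step is only a loose guide. Compound 3 is therefore expected to land near compound 1 or somewhat lower, with a 1.3-fold lower number from compound 1 to compound 3 (0.11 log units; within the scatter) as the estimated step. The estimate for compound 3 is 25 nM, in the range 8 nM to 80 nM.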

Compound 3, half-maximal inhibitory concentration: 15 nM
Beside the measured number, compound 3's estimate is 1.7-fold (0.22 log units) above it; measured number inside the range.
By their numbers in this assay, from the lowest: compounds 2 and 3 (each within the scatter of the next); then compound 1.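

In this assay the 3-(hydroxymethyl)phenyl group on a saturated ring carbon gives a 2.1-fold lower number from compound 1 to compound 3 (0.33 log units; beyond the scatter) and so moves the number in the same direction as the 3-methoxyphenyl group did, which means that this direction is no longer tied to a single replacement for 4-chlorophenyl. Hydroxymethyl in place of methoxy on an aromatic carbon gives a 1.2-fold higher number from compound 2 to compound 3 (0.06 log units; within the scatter) and leaves the two compounds indistinguishable on this read-out, even though the entering 3-(hydroxymethyl)phenyl group counts a hydrogen-bond donor that 4-chlorophenyl lacks. Nothing available here accounts for either step.

Since each replacement of 4-chlorophenyl changes both the substituent and where it sits on the phenyl ring, the compounds shown cannot separate those two changes. They also leave open whether the same number would hold with an aminomethyl group or a carboxylic acid in place of the hydroxymethyl, or with a longer chain ending in a hydroxyl group.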